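The source may hold more compounds than are shown below. What is called first, only, known or untested is meant among the compounds shown, and "the series" means these compounds.

The series rests on one shared core, seen in compound 1 `O=C1OC(c2cccc(Br)c2)=N/C1=C\c1ccncc1`, compound 2 `COc1ccc(C2=N/C(=C\c3cccnc3)C(=O)O2)cc1Br` and compound 3 `COc1ccc(C2=N/C(=C\c3cccnc3)C(=O)O2)cc1OC`. In an assay on isolated protein for inhibition of Death-associated protein kinase 3 (Homo sapiens), tested at 1 uM (on this read-out higher numbers stand for a stronger effect at the one concentration tested and lower numbers for a weaker effect), compound 2 gives 32%, the highest of the three numbers; compound 3 gives 14%, and compound 1 gives 1%, both beyond the scatter from it. Among the compounds with values here, the single step that can be read between measured compounds, a number 18 percentage points lower from compound 2 to compound 3 (beyond the scatter), comes from methoxy in place of bromo on an aromatic carbon, a modest but real loss.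

Compound 4 `O=C1OC(c2cccc(Br)c2)=N/C1=C\c1cccnc1` has not yet been measured. It differs from compound 2 in one place: hydrogen in place of methoxy on an aromatic carbon. Within the data shown here, no measured step matches this change directly. Among the measured compounds shown here, the only guidance is indirect: the loss seen from compound 2 to compound 3 shows that the groups on this ring matter, and compound 1, which carries the bromo group without a methoxy group but differs in its other ring, gives only 1%. Taking the methoxy group away from compound 2 is therefore expected to cost some of its effect, though by how much is uncertain. Compound 4 is estimated at 15%, within a range from 2% to 35%. That estimate means an expected a number 17 percentage points lower from compound 2 to compound 4 (beyond the scatter).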

Compound 4, a percentage reported as inhibition, at one concentration (the size of the read-out at that concentration, not a potency): 100%
Compound 4: the middle estimate sits 85 percentage points below what was measured; measured number above the stated range.
By their numbers in this assay, from the lowest: compound 1; then compound 3; then compound 2; then compound 4.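

In this assay, within the data shown here, hydrogen in place of methoxy on an aromatic carbon, ortho to a bromo group and para to a large group, gives a number 68 percentage points higher from compound 2 to compound 4 (beyond the scatter), so the methoxy group at this place weighs heavily against the effect in this pair, a cost the earlier compounds could not show because none of them compared methoxy with hydrogen there. The pyridine ring also proves decisive: with the bromo-bearing ring unchanged, pyridin-3-yl in place of pyridin-4-yl gives a number 99 percentage points higher from compound 1 to compound 4 (beyond the scatter), and this single change spans almost the whole range seen in the series. Nothing available explains why either change has so large an effect.

The compounds shown leave open how other groups at the methoxy position, such as fluoro, hydroxy or ethoxy, would compare with hydrogen, and whether any of them would retain the effect of compound 4. They also leave open whether removing the methoxy group would bring a similar gain with pyridin-4-yl in place of pyridin-3-yl, and how an amine on the pyridine ring would change the read-out.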